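Sulfonyl aryl swap on the shared core

This account rests on a few compounds, and the source may have more. Where it says the series, first, only, none or still open, it means among the compounds named here.

Compound 1 `CNCc1cn(S(=O)(=O)c2cccc(OC)n2)c(-c2cccnc2F)c1F` is the reference point of the series. Among the measured compounds shown here, in a physicochemical assay for lipophilicity, read by HPLC, at pH 7.4 (on this read-out lower numbers stand for lower lipophilicity and higher numbers for higher lipophilicity), compound 1 gives 1.03, the highest of the two numbers measured so far. For the measured compounds named here, compound 2 `CNCc1cn(S(=O)(=O)c2cccc(C)n2)c(-c2cccnc2F)c1F` gives 0.71 in this assay, and the only measured step, a number 0.32 log units lower from compound 1 to compound 2 (beyond the scatter), is the one that carries a methyl in place of a methoxy on an aromatic carbon.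

Compound 3 `CNCc1cn(S(=O)(=O)c2ccc(C)nc2)c(-c2cccnc2F)c1F` has not yet been measured. The change from compound 1 is 6-methylpyridin-3-yl in place of 6-methoxypyridin-2-yl on a sulfonyl sulfur. This change shares one feature with the measured step: a methyl where compound 1 has a methoxy. Going by the values given here, it also moves the point at which the pyridine ring is joined to the sulfonyl sulfur, and no measured pair covers that part of the change, so its contribution is unknown here.

On the strength of the step from compound 1 to compound 2, a modest lowering is expected, a number 0.28 log units lower from compound 1 to compound 3 (within the scatter). Compound 3 is therefore estimated at 0.75, with a range from 0.35 to 1.15, the range being widened to allow for the unmeasured shift in ring attachment.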

Compound 3, distribution coefficient: 0.62
The estimate for compound 3 lay 0.13 log units above the measured number; measured number inside the range.
By their numbers in this assay, from the lowest: compounds 3 and 2 (each within the scatter of the next); then compound 1.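

In this assay, the pair compound 2 and compound 3 gives the first read on where the pyridine ring is joined to the sulfonyl sulfur: 6-methylpyridin-3-yl in place of 6-methylpyridin-2-yl gives a number 0.09 log units lower from compound 2 to compound 3 (within the scatter) and so shows no separation between these two attachments when the ring carries a methyl. Among the compounds shown here, the wider swap of 6-methylpyridin-3-yl in place of 6-methoxypyridin-2-yl gives a number 0.41 log units lower from compound 1 to compound 3 (beyond the scatter) and leaves compound 1, the only methoxy compound of the three, with the highest number, while compound 2 and compound 3 cannot be ordered. No separate measurement bears on the reason for these numbers.

As far as these compounds go, whether the attachment point is equally silent with a methoxy on the ring remains open, and a 6-methoxypyridin-3-yl group on the sulfonyl sulfur would complete that comparison. From the compounds shown here alone, how an amine, a carboxylic acid or a longer alkyl chain in place of the methyl would read on this scale also remains open.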